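From chloro to trifluoromethyl at compound 3

A few compounds are considered here, and "the series" means these few. Any claim that something is new, unique, unknown or untested is made for them only; others in the source may bear on it.

Compound 1 `Cc1ncccc1Cn1nnnc1-c1cccc(Cl)c1Cl`: 200 nM
Compound 2 `FC(F)(F)c1cccc(-c2nnnn2Cc2cccnc2)c1Cl`: 158 nM
Compound 3 `Clc1cccc(-n2nnnc2Cc2cccnc2)c1Cl`: 398 nM

In a functional assay on THP-1 cells (Homo sapiens) for inhibition (a lower number here means a stronger inhibitor, a higher number a weaker inhibitor), compound 3 gives 398 nM. This value lies within the scatter of compound 1 and higher, beyond the scatter, than that of compound 2. Compound 4 `FC(F)(F)c1cccc(-n2nnnc2Cc2cccnc2)c1Cl` differs from compound 3 by trifluoromethyl in place of chloro on an aromatic carbon, ortho to a chloro group and meta to a large group: trifluoromethyl in place of chloro on an aromatic carbon. For the measured compounds named here, no measured pair shows this change alone. Compound 2 also carries trifluoromethyl and gives 158 nM, so a small move toward a lower number is expected, within the scatter. The expected step is a 1.6-fold lower number from compound 3 to compound 4 (0.20 log units; within the scatter). For compound 4 the estimated value is 250 nM, with an expected range of 100 nM to 630 nM.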

Compound 4, half-maximal inhibitory concentration: 50.1 nM
The estimate for compound 4 lay 5.0-fold (0.70 log units) above the measured number; measured number outside the range, below it.
By their numbers in this assay, from the lowest: compound 4; then compounds 2, 1 and 3 (each within the scatter of the next, the first and the last beyond it).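

In this assay, trifluoromethyl in place of chloro on an aromatic carbon, ortho to a chloro group and meta to a large group, gives a 7.9-fold lower number from compound 3 to compound 4 (0.90 log units; beyond the scatter), a step beyond the scatter. This is the first change in one place among these compounds, and it shows that this position responds clearly to the exchange. Nothing at hand accounts for the size of the step. From the compounds shown here alone, how a nitrile, a methyl group or a methoxy group on this carbon would compare remains open. So does whether the step depends on the chloro group that stays in place.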